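Dropping a Chloro Group: An Expected Gain in Potency

The source may report more compounds than this note shows. Statements on the series, on what has been measured and on what is new or still open speak of the compounds shown alone.

Measured compounds:
- compound 1 `ClCc1ccc(Cn2cnc3c(Cl)ncnc32)cc1`: 3460 nM
- compound 2 `ClCc1ccccc1Cn1cnc2nc(Cl)nc(Cl)c21`: 35500 nM
- compound 3 `ClCc1ccc(Cn2cnc3c(Cl)nc(Cl)nc32)cc1`: 19500 nM

These three compounds share a core and were tested in a functional assay on SF-295 cells (Homo sapiens) for cytotoxicity, read by sulforhodamine B assay, with a stated time of 48 h; a higher number here means a weaker inhibitor of growth, a lower number a stronger inhibitor of growth. Compound 2 stands at the weak end of the set: its number and that of compound 3 differ only within the usual scatter, while compound 1 sits well below both, beyond the scatter.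

The unmeasured compound 4 `ClCc1ccccc1Cn1cnc2ncnc(Cl)c21` differs from compound 2 in one place:

hydrogen in place of chloro on an aromatic carbon

Among the compounds with values here, one measured step bears on this change, but in the opposite direction. Going from compound 1 to compound 3 adds a chloro group at the same kind of position, and the number rises: a 5.6-fold higher number from compound 1 to compound 3 (0.75 log units; beyond the scatter). Compound 4 removes that chloro group from compound 2, so the reverse is expected: a fall in the number of roughly the same size, comfortably beyond the scatter. Because compound 2 gives 35500 nM in this assay and the added chloro group cost about a 5.6-fold higher number from compound 1 to compound 3 (0.75 log units; beyond the scatter), compound 4 is expected to come in around 6500 nM, a step of a 5.5-fold lower number from compound 2 to compound 4 (0.74 log units; beyond the scatter). The estimated range runs from 2500 nM to 18000 nM.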

Compound 4, concentration for total growth inhibition: 20400 nM
Compound 4: the middle estimate sits 3.1-fold (0.50 log units) below what was measured, and the stated range ends below it.
By their numbers in this assay, from the lowest: compound 1; then compounds 3, 4 and 2 (each within the scatter of the next).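

In this assay, replacing the chloro group between two ring nitrogen atoms with hydrogen gives a 1.7-fold lower number from compound 2 to compound 4 (0.24 log units; within the scatter), so on this core the change does not clearly separate the two compounds. Within the data shown here, the earlier pair showed the change on only one core, where the chloro group came with a clear loss of growth inhibition; compound 2 and compound 4 show that this loss does not carry over in full, and that the same swap at this position can count for much or little depending on the rest of the molecule: the same change on two cores in this assay, a 5.6-fold higher number (0.75 log units; beyond the scatter) from compound 1 to compound 3 and a 1.7-fold higher number (0.24 log units; within the scatter) from compound 4 to compound 2, 3.2-fold (0.51 log units) apart, beyond the scatter of two such steps. A step read on one core is therefore only a rough guide to the same step on another, and this position now has to be judged core by core.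

From the compounds shown here alone, what in the two cores produces this gap stays open, and two pairs cannot show which of them is the more typical. It is also unknown how this position would respond on either core to an amine or a methoxy group, which would show whether anything other than hydrogen or chloro moves the number beyond the scatter.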